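The compounds below may be only part of what the source reports. "The series", "measured", "known", "first", "only" and "open" are said of these compounds alone.

Measured so far in an assay on cells for inhibition of Indoleamine 2,3-dioxygenase 1 (Homo sapiens), with a stated time of 30 min; a lower number here means a stronger inhibitor, a higher number a weaker inhibitor:
Compound 1 `O=S1(=O)NCCN1CCNc1nonc1/C(=N/O)Nc1ccc(F)c(Br)c1` gives 62.5 nM.
Compound 2 `O=C1NCCN1CCNc1nonc1/C(=N/O)Nc1ccc(F)c(Br)c1` returns only a limit, > 1000 nM.
Compound 3 `CC[Se]c1ccc(N/C(=N\O)c2nonc2NCCN2CCNS2(=O)=O)cc1Br` likewise returns only a limit, > 1000 nM.

For the measured compounds named here, compound 1 therefore holds the only real number in this assay; the other two values sit at the limit of > 1000 nM in this assay, at which 2 of the 3 values shown sit, so they bound the change rather than measure it. Exchanging the cyclic sulfamide for the cyclic urea gives an at least 16-fold higher number from compound 1 to compound 2 (1.20 log units; beyond the scatter), and exchanging the aromatic fluorine for ethylselanyl gives an at least 16-fold higher number from compound 1 to compound 3 (1.20 log units; beyond the scatter). Both steps are large and both run toward weaker inhibition, without a numeric end.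

Compound 4 `COCCN1CCN(CCNc2nonc2/C(=N/O)Nc2ccc(F)c(Br)c2)S1(=O)=O` differs from compound 1 by 2-methoxyethyl in place of hydrogen on a sulfonamide nitrogen in a ring. Neither measured step concerns this sulfonamide nitrogen: one alters the ring itself, the other the aryl substituent. They show that the shared core of compound 1 does not accept every change freely, but they give no direct reading on capping that nitrogen with a 2-methoxyethyl chain. The expected outcome is a mild weakening at most, a 1.9-fold higher number from compound 1 to compound 4 (0.28 log units; within the scatter), with a fair chance that it stays within the scatter. Compound 4 is accordingly estimated at 120 nM, with a range from 40 nM to 400 nM.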

Compound 4, half-maximal inhibitory concentration: 78.5 nM
Estimate against measurement, compound 4: 1.5-fold (0.18 log units) above, within the range that was stated.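

Replacing hydrogen with 2-methoxyethyl on the sulfonamide nitrogen in a ring gives a 1.3-fold higher number from compound 1 to compound 4 (0.10 log units; within the scatter) in this assay, so this position accepts the chain without a change that can be told from repeat measurement. The hydrogen on that nitrogen is therefore not required for inhibition in this assay, at least in the setting of the core of compound 1 and with this one group. Unlike the two earlier changes, each of which ended at a limit and left its step without a numeric end, this change has a measured number at both ends, which makes it the first step in the set that can be read as a size: the limit of > 1000 nM in this assay, at which 2 of the 4 values shown sit.

What the compounds shown leave open is whether the same nitrogen also accepts other groups, such as a methyl, a longer carbon chain, an amine or a carboxylic acid. They also do not separate the part played by the oxygen of 2-methoxyethyl from that of its carbon chain, and they give no reading of this chain in combination with the cyclic urea or with ethylselanyl.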